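The compounds below may be only part of what the source reports. "The series", "measured", "known", "first", "only" and "open" are said of these compounds alone.

Measured so far in a functional assay on K562 cells (Homo sapiens), read by MTT assay, with a stated time of 72 h; on this read-out lower numbers stand for stronger inhibition and higher numbers for weaker inhibition:

compound 1, `COc1ncnc2c1c(-c1cccs1)cn2[C@@H]1O[C@H](CO)[C@@H](O)[C@H]1O`: 6200 nM
compound 2, `COc1nc(N)nc2c1c(-c1cccs1)cn2[C@@H]1O[C@H](CO)[C@@H](O)[C@H]1O`: > 20000 nM, which is a limit of the assay and not a number
compound 3, `O=c1[nH]cnc2c1c(-c1ccccc1)cn2[C@@H]1O[C@H](CO)[C@@H](O)[C@H]1O`: > 20000 nM, which is likewise a limit of the assay

Compound 1 and compound 2 share one core; compound 3 and the unmeasured compound 4, `Nc1nc2c(c(-c3ccccc3)cn2[C@@H]2O[C@H](CO)[C@@H](O)[C@H]2O)c(=O)[nH]1`, share another. The difference between the two cores is not broken down here.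

The change from compound 1 to compound 2 is amino in place of hydrogen on an aromatic carbon. In this assay it gave an at least 3.2-fold higher number from compound 1 to compound 2 (0.50 log units; beyond the scatter); the size of that step is known only as a bound because of the limit of > 20000 nM in this assay, at which 2 of the 3 values shown sit.

The change from compound 3 to compound 4 is amino in place of hydrogen on an aromatic carbon. This is the same kind of change, not the same one: around the place, the entering group is meta to a methoxy group (2 heavy atoms) in the first pair and meta to a group of 1 heavy atom in the second.

Compound 3 gives only a limit in this assay. Against that background the step that the limit leaves unreadable from compound 3 to compound 4 is expected, resting on the step of an at least 3.2-fold higher number from compound 1 to compound 2 (0.50 log units; beyond the scatter) pointing toward weaker inhibition and on the starting point already sitting at the limit. Compound 4 is therefore expected to give 40000 nM, with an expected range from 15000 nM to 200000 nM, most probably reported as a limit once more.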

Compound 4, half-maximal inhibitory concentration: > 20000 nM
Compound 4: a limit, no number (the forecaster's own chance of this, stated with the estimate: 90%); the middle value is on the limit's open side.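

Compound 3 and compound 4 each give only a limit and not a number, so no step between them can be read, because neither result goes past the same ceiling: the limit of > 20000 nM in this assay, at which 3 of the 4 values shown sit.

The compounds shown leave open whether amino in place of hydrogen on an aromatic carbon changes inhibition at all on the core of compound 3, and how far compound 3 and compound 4 actually lie apart.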